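The source may hold more compounds than are shown below. What is called first, only, known or untested is meant among the compounds shown, and "the series" means these compounds.

In a functional assay on A549 cells (Homo sapiens) for antiproliferative activity, with a stated time of 5 days (a lower number here means a stronger inhibitor, a higher number a weaker inhibitor), compound 1 `COc1ccc(-n2nc(-c3ccc4ccccc4c3)nc2N2C(=O)COC23C=CC(=O)C=C3)cc1` gives 260 nM and lies within the usual scatter of compound 2 `O=C1C=CC2(C=C1)OCC(=O)N2c1nc(-c2ccc3ncccc3c2)nn1-c1ccccc1` at 170 nM and compound 3 `CC1OC2(C=CC(=O)C=C2)N(c2nc(-c3cccc4ccccc34)nn2-c2ccccc2)C1=O` at 180 nM on this measure. On these numbers, the three cannot be told apart. Compound 4 `Cc1ccc(-n2nc(-c3ccc4ccccc4c3)nc2N2C(=O)COC23C=CC(=O)C=C3)cc1` keeps the core of compound 1 and changes one group, with methyl in place of methoxy on an aromatic carbon is the whole difference. For the measured compounds named here, no measured pair differs in just one place, so nothing here shows directly what this change does. With compound 1 at 260 nM as the starting point, no shift beyond the scatter is expected in either direction. The estimated step of a 1.2-fold lower number from compound 1 to compound 4 (0.07 log units; within the scatter) is correspondingly small. Compound 4 is expected at 220 nM with 100 nM to 480 nM as its estimated range.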

Compound 4, half-maximal inhibitory concentration: 110 nM
Estimate against measurement, compound 4: 2.0-fold (0.30 log units) above, and the stated range covers the measured number.
By their numbers in this assay, from the lowest: compounds 4, 2, 3 and 1 (each within the scatter of the next, the first and the last beyond it).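

For the compounds shown here, the pair gives the first direct reading at this position: in this assay, changing 4-methoxyphenyl to 4-methylphenyl gives a 2.4-fold lower number from compound 1 to compound 4 (0.37 log units; beyond the scatter) on an otherwise unchanged structure. This place, para to a large group, therefore responds to a change as small as methyl in place of methoxy, and the activity of compound 4 does not depend on having methoxy there. Nothing available explains why the number moves. Still open, going by these compounds, is whether ethyl, chlorine or an amine at the same place would move the number further, and whether the same change holds in compound 2 and compound 3.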